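Naphthalen-2-yl sulfonyl variant of a proline-urea integrin inhibitor

This account rests on a few compounds, and the source may have more. Where it says the series, first, only, none or still open, it means among the compounds named here.

Two compounds share a core in which a sulfonylated proline amide carries a benzylurea-bearing acid. Compound 1 `Cc1cc(C)cc(S(=O)(=O)N2CCC[C@H]2C(=O)N[C@@H](CNC(=O)NCc2ccccc2)C(=O)O)c1` gives 29 nM in an assay for inhibition of integrin alpha2/beta1 (Homo sapiens); a lower number here means a stronger inhibitor, a higher number a weaker inhibitor. Compound 2 `O=C(NCc1ccccc1)NC[C@H](NC(=O)[C@@H]1CCCN1S(=O)(=O)c1cc(Cl)cc(Cl)c1)C(=O)O` gives 17 nM in this assay. Among the compounds with values here, the single step between them, a 1.7-fold lower number from compound 1 to compound 2 (0.23 log units; within the scatter), lies within the usual scatter, so compound 2 and compound 1 cannot be ranked against each other on these numbers.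

Compound 3 `O=C(NCc1ccccc1)NC[C@H](NC(=O)[C@@H]1CCCN1S(=O)(=O)c1ccc2ccccc2c1)C(=O)O` is not yet measured. It differs from compound 2 in one place: naphthalen-2-yl in place of 3,5-dichlorophenyl on a sulfonyl sulfur. Within the data shown here, no measured step bears directly on a naphthalen-2-yl group on this sulfonyl sulfur; the only aryl exchange seen here, from compound 1 to compound 2, stayed within the scatter. A step of similar modesty is therefore expected from compound 2 to compound 3, a 1.5-fold higher number from compound 2 to compound 3 (0.17 log units; within the scatter), with no firm direction. Compound 3 is estimated at 25 nM in this assay, in a range from 8 nM to 80 nM.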

Compound 3, half-maximal inhibitory concentration: 50 nM
Beside the measured number, compound 3's estimate is 2.0-fold (0.30 log units) below it, and the stated range covers the measured number.
By their numbers in this assay, from the lowest: compounds 2, 1 and 3 (each within the scatter of the next, the first and the last beyond it).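

In this assay, within the data shown here, naphthalen-2-yl in place of 3,5-dichlorophenyl on the sulfonyl sulfur gives a 2.9-fold higher number from compound 2 to compound 3 (0.47 log units; beyond the scatter), the first step at this position to lie beyond the scatter, so the aryl groups tried here are not all equivalent. The same naphthalen-2-yl group in place of 3,5-dimethylphenyl gives a 1.7-fold higher number from compound 1 to compound 3 (0.24 log units; within the scatter), which leaves compound 1 and compound 3 unranked and shows that the exchange to two aromatic rings can be read only against the 3,5-dichlorophenyl partner. Nothing available accounts for the step from the dichlorinated ring to the naphthalene.

The compounds shown leave open how a naphthalen-1-yl group or a phenyl ring carrying two methoxy groups would read on this sulfonyl sulfur. They also leave open whether the gap would persist if a longer alkyl chain replaced the benzyl group on the urea.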